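Expected Lipophilicity after Adding a Bromo Group

A few compounds are considered here, and "the series" means these few. Any claim that something is new, unique, unknown or untested is made for them only; others in the source may bear on it.

Compound 1 `O=C(CSc1nc2ccccc2s1)N/N=C/c1ccc(Oc2ccccc2)cc1`: in a physicochemical assay for lipophilicity, in phosphate buffer, measured as octanol-water partition, with a stated time of 24 h (on this read-out lower numbers stand for lower lipophilicity and higher numbers for higher lipophilicity), compound 1 gives 5.6.
Compound 2 `O=[N+]([O-])c1ccc(Oc2ccc(/C=N/Nc3nc4ccccc4s3)cc2)cc1`: in this assay compound 2 gives 5.1.

Compound 1 stands highest of the two numbers; its nearest neighbour is compound 2, whose number sits lower by an amount beyond the usual scatter. Compound 3 `O=C(CSc1nc2ccccc2s1)N/N=C/c1ccc(Oc2ccc(Br)cc2)cc1` differs from compound 1 by bromo in place of hydrogen on an aromatic carbon, in words bromo in place of hydrogen on an aromatic carbon. Among the measured compounds shown here, no pair of measured compounds shows what this change does here. Compound 3 is expected to move upward in this assay, by a step of a number 0.80 log units higher from compound 1 to compound 3 (beyond the scatter) that lies beyond the scatter. Compound 3 is estimated at 6.4, with a range from 6 to 6.8.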

Compound 3, partition coefficient: 5.7
The estimate for compound 3 lay 0.70 log units above the measured number; the whole stated range lies above it.
By their numbers in this assay, from the lowest: compound 2; then compounds 1 and 3 (each within the scatter of the next).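

In this assay, going from phenoxy to 4-bromophenoxy gives a number 0.10 log units higher from compound 1 to compound 3 (within the scatter) as its step. Among the compounds shown here, this is the first direct reading of this change: at this place, para to a large group, swapping hydrogen for bromo leaves compound 1 and compound 3 indistinguishable on this read-out. Nothing measured here offers a reason for this result.

Still open, from the compounds shown here alone, is whether an amine or a carboxylic acid at this same place would also stay within the scatter of compound 1. Also open, going by these compounds, is whether bromo on another ring of compound 1 would behave the same way.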